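Replacing a Sulfonamide with a Urea at the Anilide Nitrogen

A few compounds are considered here, and "the series" means these few. Any claim that something is new, unique, unknown or untested is made for them only; others in the source may bear on it.

Compound 1 `COc1cccc(S(=O)(=O)Nc2cccc(-c3nc(-c4ccc(NC(=O)c5cccnc5)cc4Cl)no3)c2)c1` is the starting point. In a functional assay on MDA-MB-231 cells (Homo sapiens) for antiproliferative activity, read by MTT assay, with a stated time of 72 h (a higher number here means a weaker inhibitor, a lower number a stronger inhibitor), compound 1 gives > 10000 nM, which is a limit of the measurement rather than a number, so it sits at the weak end of the values shown (the limit of > 10000 nM in this assay, at which 1 of the 2 values shown sits). Compound 2 `CNC(=O)Nc1ccc(S(=O)(=O)Nc2cccc(-c3nc(-c4ccc(NC(=O)c5cccnc5)cc4Cl)no3)c2)cc1` differs from compound 1 only on the sulfonyl sulfur, and in this assay compound 2 gives 1300 nM; that change amounts to an at least 7.6-fold lower number from compound 1 to compound 2 (0.88 log units; beyond the scatter).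

Compound 3 `C#Cc1ccc(NC(=O)Nc2cccc(-c3nc(-c4ccc(NC(=O)c5cccnc5)cc4Cl)no3)c2)cc1` has not yet been measured. It differs from compound 1 as follows: (4-ethynylphenyl)carbamoyl in place of (3-methoxyphenyl)sulfonyl on a nitrogen on an aromatic ring. Within the data shown here, the one measured step that touches this part of the molecule is the step from compound 1 to compound 2, which was at least modest and pointed toward stronger inhibition; its exact size is unknown because compound 1 sits at the limit (the limit of > 10000 nM in this assay, at which 1 of the 2 values shown sits). Compound 3 also moves away from the sulfonyl group of compound 1, so a step in the same direction is expected, with considerable uncertainty about its size. Compound 3 is expected to reach about 2500 nM, between 500 nM and 12000 nM, an expected step of an at least 4.0-fold lower number from compound 1 to compound 3 (0.60 log units; beyond the scatter).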

Compound 3, half-maximal inhibitory concentration: > 10000 nM
Compound 3 was reported as a limit (the forecaster's own chance of this, stated with the estimate: 30%); at least 4.0-fold (0.60 log units) between middle value and limit.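

Compound 1 and compound 3 both sit at the limit of the measurement, so no step between them can be read: the limit of > 10000 nM in this assay, at which 2 of the 3 values shown sit.

The compounds shown leave open whether (4-ethynylphenyl)carbamoyl in place of (3-methoxyphenyl)sulfonyl on that nitrogen changes antiproliferative activity at all, and by how much.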